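The compounds below may be only part of what the source reports. "The series", "measured", "known", "first", "only" and "open" are said of these compounds alone.

Compound 1 `COc1ccccc1C(=O)Nc1ccc(Cl)cc1CN1C(=O)c2ccccc2C1=O` and compound 2 `CCOc1cccc2c1C(=O)N(Cc1cc(Cl)ccc1NC(=O)c1ccccn1)C2=O` share a core that carries an amide on one side. In an assay on CHO cells for positive allosteric modulation of metabotropic glutamate receptor 5 (Homo sapiens), read by FLIPR (a lower number here means that less compound is needed, a higher number that more compound is needed for the effect), compound 1 gives only > 100000 nM, which is a limit of the assay and not a number, namely (the limit of > 100000 nM in this assay, at which 1 of the 2 values shown sits). In this assay compound 2 gives 280 nM. Compound 3 `O=C(Nc1ccc(Cl)cc1CN1C(=O)c2ccccc2C1=O)c1ncccc1O` differs from compound 1 by 3-hydroxypyridin-2-yl in place of 2-methoxyphenyl on a carbonyl carbon. Going by the values given here, no measured step of this kind is known here. Compound 3 is expected to need much less compound, a step of an at least 33-fold lower number from compound 1 to compound 3 (1.52 log units; beyond the scatter) being estimated. Compound 3 is therefore expected to give 3000 nM in this assay, between 500 nM and 30000 nM.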

Compound 3, half-maximal effective concentration: 260 nM
Beside the measured number, compound 3's estimate is 12-fold (1.06 log units) above it, and the stated range ends above it.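

In this assay, 3-hydroxypyridin-2-yl in place of 2-methoxyphenyl on this carbonyl carbon gives an at least 380-fold lower number from compound 1 to compound 3 (2.58 log units; beyond the scatter), so a change at this one position can take the shared core from a limit to a measured number. Compound 1 stands at a limit of the assay and not at a number, so the true size of the step remains open-ended: the limit of > 100000 nM in this assay, at which 1 of the 3 values shown sits.

The ring nitrogen and the hydroxy group enter together, so the compounds shown cannot separate their contributions. From the compounds shown here alone, whether an amine in place of that hydroxy group would serve equally well also remains open.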